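Nitrophenyl Ureas and Thioureas in a Cytotoxicity Screen

The source may hold more compounds than are shown below. What is called first, only, known or untested is meant among the compounds shown, and "the series" means these compounds.

This account covers three measured compounds and one still to be measured, all carrying a nitrophenyl group on an amide-type nitrogen. Compound 1 `COc1ccc(Oc2ccccc2-c2ccsc2S(=O)(=O)N2CCN(C(=O)Nc3cccc([N+](=O)[O-])c3)CC2)cc1OC` bears a urea, while compound 2 `O=[N+]([O-])c1ccc(NC(=S)NCCNS(=O)(=O)c2ccc(-c3ccccc3OCc3cccc(O)c3)s2)cc1` and compound 3 `O=[N+]([O-])c1cccc(NC(=S)NCCNS(=O)(=O)c2ccc(-c3ccccc3OCc3cccc(O)c3)s2)c1` bear a thiourea on a different core; how the core of compound 1 and the core of compound 3 differ is not broken down here.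

In an ADME assay on HEK-293T cells (Homo sapiens) for cytotoxicity, read by CCK-8 assay, with a stated time of 48 h (on this read-out higher numbers stand for weaker inhibition and lower numbers for stronger inhibition), compound 3 gives 13800 nM. For compound 2 this assay reports only a limit, > 20000 nM. For compound 1 this assay likewise reports only a limit, > 20000 nM. The change 4-nitrophenyl in place of 3-nitrophenyl on an amide-type nitrogen gives an at least 1.4-fold higher number from compound 3 to compound 2 (0.16 log units; that floor lies within the scatter), and that step runs up to the limit of > 20000 nM in this assay, at which 2 of the 3 values shown sit.

Compound 4 `COc1ccc(Oc2ccccc2-c2ccsc2S(=O)(=O)N2CCN(C(=O)Nc3ccc([N+](=O)[O-])cc3)CC2)cc1OC` is not yet measured. It arises from compound 1 by 4-nitrophenyl in place of 3-nitrophenyl on an amide-type nitrogen, the same kind of change as that from compound 3 to compound 2, though the amide-type nitrogen here has a carbonyl carbon as its other neighbour rather than a thiocarbonyl carbon. Since compound 1 already sits at a limit, > 20000 nM, and the related change from compound 3 to compound 2 gave an at least 1.4-fold higher number from compound 3 to compound 2 (0.16 log units; that floor lies within the scatter), compound 4 is expected to remain at that limit, an estimated step that the limit leaves unreadable from compound 1 to compound 4. The expected value for compound 4 in this assay is 25000 nM, with a range from 12000 nM to 60000 nM.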

Compound 4, half-maximal inhibitory concentration: > 20000 nM
Compound 4 ended at the assay's limit; the forecaster's own chance of this, stated with the estimate: 85%; the middle value is on the limit's open side.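

In this assay compound 4 gives > 20000 nM, which is a limit and not a number. No step can be read between compound 1 and compound 4, since both stand at a limit: the limit of > 20000 nM in this assay, at which 3 of the 4 values shown sit. The compounds shown leave open where the true values of compound 1 and compound 4 lie, and whether 4-nitrophenyl in place of 3-nitrophenyl makes any difference on the core of compound 1.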